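The source may report more compounds than this note shows. Statements on the series, on what has been measured and on what is new or still open speak of the compounds shown alone.

Compound 1, `CC[C@H](CCn1cncn1)c1ccc(C)cc1`, gives 85.2 ug/mL in an ADME assay on RD cells (Homo sapiens) for cytotoxicity, read by MTT assay, with a stated time of 3 days (a lower number here means that less compound is tolerated, a higher number that more compound is tolerated), the highest of the two numbers recorded so far. Its neighbour compound 2, `CC[C@@H](CCn1cncn1)c1ccc(C)cc1`, gives 79.4 ug/mL in this assay, and the step of a 1.1-fold lower number from compound 1 to compound 2 (0.03 log units; within the scatter) rests on the fact that the two compounds differ only in the configuration as drawn (the fact that compounds 1 and 2 differ only in the configuration as drawn). The unmeasured compound 3, `CCCC[C@H](CCn1cncn1)c1ccc(C)cc1`, differs from compound 1 by ethyl in place of hydrogen on a saturated chain carbon, three bonds along the chain from an aromatic carbon. Among the compounds with values here, no measured step bears directly on this change: the only step recorded is the one from compound 1 to compound 2, which is a change of configuration and lies within the scatter, so it tells nothing about lengthening the chain. With no guidance beyond that, the author expects the step of a 1.3-fold lower number from compound 1 to compound 3 (0.12 log units; within the scatter) to be small and possibly not beyond the scatter. For compound 3 in this assay the author therefore estimates 65 ug/mL, within a range from 30 ug/mL to 130 ug/mL.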

Compound 3, half-maximal cytotoxic concentration: 26.5 ug/mL
Compound 3: the middle estimate sits 2.5-fold (0.39 log units) above what was measured; the whole stated range lies above it.
By their numbers in this assay, from the lowest: compound 3; then compounds 2 and 1 (each within the scatter of the next).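

Where the change of configuration gave only a 1.1-fold lower number from compound 1 to compound 2 (0.03 log units; within the scatter), ethyl in place of hydrogen on a saturated chain carbon, three bonds along the chain from an aromatic carbon, gives a 3.2-fold lower number from compound 1 to compound 3 (0.51 log units; beyond the scatter) in this assay, so this position is one where the number moves beyond the scatter, with less compound tolerated once the ethyl group is present. The same difference can be read as ethyl to butyl, and the earlier pair, which shared the ethyl group, could not show this. Nothing recorded about these compounds accounts for the drop.

What the compounds shown leave open is how the number runs with chain length, since a propyl group or a chain longer than butyl would be needed to tell a trend from a single step. They also leave open whether an amine or a carboxylic acid at the end of this chain would behave like the ethyl group, and whether configuration still makes so little difference in the butyl series.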